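Replacing Methylsulfonyl with an Amide: Expected Solubility

A few compounds are considered here, and "the series" means these few. Any claim that something is new, unique, unknown or untested is made for them only; others in the source may bear on it.

Three compounds built on one shared core were tested in a physicochemical assay for solubility, read by HPLC, in phosphate buffer, with a stated time of 24 h, at pH 6.8; a lower number here means a less soluble compound, a higher number a more soluble compound. Compound 1 `CC(C)OC(=O)N1CCC2(CC1)CC(CCCOc1ccc(S(C)(=O)=O)cc1)C2` gives 0.17 ug/mL in this assay. Compound 2 `CC(C)OC(=O)N1CCC2(CC1)CC(CCCOc1ccc(S(C)(=O)=O)c(F)c1)C2` carries a fluoro in place of hydrogen on an aromatic carbon; its result of < 0.16 ug/mL is a limit of this assay, not a number. That change is an at least 1.0-fold lower number from compound 1 to compound 2 (0.02 log units; that floor lies within the scatter). Compound 3 `CC1(OC(=O)N2CCC3(CC2)CC(CCCOc2ccc(S(C)(=O)=O)c(F)c2)C3)CC1` carries 1-methylcyclopropyl in place of isopropyl on an oxygen next to a carbonyl group; its result of < 0.15 ug/mL is likewise a limit. That change is a step that the two limits leave unreadable from compound 2 to compound 3. Compound 2 thus stands at a limit, and one further value shown is also a limit.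

Compound 4 `CC(C)OC(=O)N1CCC2(CC1)CC(CCCOc1ccc(C(=O)NCC(N)=O)c(F)c1)C2` differs from compound 2 by (carbamoylmethyl)carbamoyl in place of methylsulfonyl on an aromatic carbon. For the measured compounds named here, neither measured step alters this part of the molecule, so no measured step bears directly on it; what is known is that the change brings in two hydrogen-bond donors where the departing group had none. The expected step is an at least 12-fold higher number from compound 2 to compound 4 (1.09 log units; beyond the scatter), toward a more soluble compound. Compound 4 is estimated at 2 ug/mL, within a range from 0.3 ug/mL to 15 ug/mL.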

Compound 4, solubility: 1.77 ug/mL
For compound 4 the middle estimate is 1.1-fold (0.05 log units) above the measured one; measured number inside the range.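

For the compounds shown here, the earlier compounds changed only the fluoro and the group on the oxygen; this result is the first to touch the group on the aromatic carbon ortho to the fluoro group. In this assay, going by these compounds alone, the change at this place is an at least 11-fold higher number from compound 2 to compound 4 (1.04 log units; beyond the scatter), the only step in this set whose size lies beyond the scatter. Compound 2 stands at a limit, so this step gives only a floor: the limit of < 0.16 ug/mL in this assay, at which 1 of the 4 values shown sits.

The compounds shown do not tell whether the whole (carbamoylmethyl)carbamoyl group is needed, or whether a simple methyl amide, a carboxylic acid or an amine at this place would give a similar result. They also leave open how the same change behaves without the fluoro, or with 1-methylcyclopropyl in place of isopropyl.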